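The compounds below may be only part of what the source reports. "The series", "measured", "known", "first", "only" and "open" are said of these compounds alone.

Measured so far:
Compound 1, `CC(C)(C)OC(=O)N1CCC(CCOC(=O)N2CCc3c2ccc(S(C)(=O)=O)c3Cl)CC1`, gives 3.6 in a physicochemical assay for lipophilicity, read by HPLC, measured as octanol-water partition, at pH 7.4; a higher number here means a more lipophilic compound, a lower number a more polar compound.
Compound 2, `Cc1c(S(C)(=O)=O)ccc2c1CCN2C(=O)OCCC1CCN(C(=O)OC(C)(C)C)CC1`, gives 3.4.
Compound 3, `CC(C)(C)OC(=O)N1CCC(CCOC(=O)N2CCc3cc(S(C)(=O)=O)cc(Cl)c32)CC1`, gives 3.2.

Compound 1 and compound 2 differ in one place: methyl in place of chloro on an aromatic carbon. That change gave a number 0.20 log units lower from compound 1 to compound 2 (within the scatter). Compound 3 has the same atoms as compound 1, joined differently; the difference between the two cores is not broken down here. Compound 4, `Cc1cc(S(C)(=O)=O)cc2c1N(C(=O)OCCC1CCN(C(=O)OC(C)(C)C)CC1)CC2`, has not yet been measured and differs from compound 3 by methyl in place of chloro on an aromatic carbon. This is the same kind of change as from compound 1 to compound 2, but the place differs: in compound 1 the chloro is ortho to a methylsulfonyl group, in compound 3 it is meta to it. Among the measured compounds shown here, with only one earlier example to rest on, the step from compound 3 to compound 4 in this assay is expected to be about a number 0.20 log units lower from compound 3 to compound 4 (within the scatter), by analogy with a number 0.20 log units lower from compound 1 to compound 2 (within the scatter). Compound 4 is thus estimated at 3, between 2.7 and 3.3.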

Compound 4, distribution coefficient: 3.2
For compound 4 the middle estimate is 0.20 log units below the measured one, within the range that was stated.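

In this assay the swap of chloro for methyl gave no change at the digits printed from compound 3 to compound 4 (within the scatter) and on the other core it gave a number 0.20 log units lower from compound 1 to compound 2 (within the scatter) so on both cores the swap stays within the usual scatter of repeated measurements. Two pairs cannot show that this carries over to further cores, and steps this small cannot separate any influence of where the group sits from that scatter. Nothing shown here offers an explanation for the result.

The compounds shown carry only chloro or methyl at this place on the aromatic ring. As far as these compounds go, how an amine, a carboxylic acid or a longer chain there would read in this assay remains open.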